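Lactam swap at the amide-linked chain in the arylpiperazine series

This account rests on a few compounds, and the source may have more. Where it says the series, first, only, none or still open, it means among the compounds named here.

Three compounds of the series have numbers in an assay on COS cells for binding affinity to Alpha-1A adrenergic receptor (Homo sapiens); on this read-out higher numbers stand for weaker inhibition and lower numbers for stronger inhibition. Compound 1 `CC(C)Oc1ccccc1N1CCN(CCN(C)C(=O)CN2CCCCC2=O)CC1` gives 53 nM. Compound 2 `COc1ccccc1N1CCN(CCCNC(=O)CN2CCCCC2=O)CC1` gives 98 nM. Among the measured compounds shown here, compound 3 `CCOC(=O)C1CCC(=O)N1CC(=O)NCCN1CCN(c2ccccc2OC(C)C)CC1` gives 20 nM, the lowest number of the three, separated from compound 1 and from compound 2 by gaps that lie beyond the usual scatter, so compound 3 is the most potent compound measured so far.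

Compound 4 `CC(C)Oc1ccccc1N1CCN(CCNC(=O)CN2CCCCCC2=O)CC1` is not yet measured. It differs from compound 3 in one place: 2-oxoazepan-1-yl in place of 2-(ethoxycarbonyl)-5-oxopyrrolidin-1-yl on a saturated chain carbon bound to a carbonyl carbon. The shared core, with the isopropoxy-substituted aryl on the piperazine and the two-carbon linker to a secondary amide, is kept; what changes is the ring carried on the carbon bound to the amide carbonyl, and with it the ester and two of the hydrogen-bond acceptors counted above disappear. For the measured compounds named here, no pair of measured compounds differs in this ring alone, so the data give no direct step for it. Compound 1 and compound 2 both carry a smaller lactam at that position and show higher numbers than compound 3, which is the only pointer available.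

For compound 4 the expected change is a modest rise in this assay, estimated as a 2.0-fold higher number from compound 3 to compound 4 (0.30 log units; within the scatter), roughly at the edge of the scatter. The estimated value of compound 4 is 40 nM, with a range from 15 nM to 120 nM.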

Compound 4, inhibition constant: 18 nM
For compound 4 the middle estimate is 2.2-fold (0.35 log units) above the measured one, within the range that was stated.
By their numbers in this assay, from the lowest: compounds 4 and 3 (each within the scatter of the next); then compounds 1 and 2 (each within the scatter of the next).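

In this assay, the exchange on a saturated chain carbon bound to a carbonyl carbon gives a 1.1-fold lower number from compound 3 to compound 4 (0.05 log units; within the scatter), so 2-oxoazepan-1-yl and 2-(ethoxycarbonyl)-5-oxopyrrolidin-1-yl cannot be told apart on this read-out. For this pair, then, the position accepts a seven-membered lactam in place of a five-membered one, and the loss of the ethoxycarbonyl group, with no step beyond the scatter; the ester is not needed for compound 4 to match compound 3. Nothing at hand accounts for this lack of a measurable step.

Ring size and the ester change together in this one step, so their separate contributions cannot be read, and either could offset the other. From the compounds shown here alone, it remains open whether a carboxylic acid in place of the ethoxycarbonyl group, or an open-chain amide or a tertiary amine in place of the lactam, would keep the number in the same range at this position.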